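This account rests on a few compounds, and the source may have more. Where it says the series, first, only, none or still open, it means among the compounds named here.

In a functional assay on SK-BR-3 cells (Homo sapiens) for antiproliferative activity (a higher number here means a weaker inhibitor, a lower number a stronger inhibitor), compound 1 `CCNCCCOc1ccc2cc(NC(=O)c3ccc(O)c(CC=C(C)C)c3)c(=O)oc2c1C` gives 720 nM and compound 2 `CCN(CC)CCCOc1ccc2cc(NC(=O)c3ccc(O)c(CC=C(C)C)c3)c(=O)oc2c1C` gives 4900 nM while compound 3 `CC(C)=CCc1cc(C(=O)Nc2cc3ccc(OCCCN(C)C(C)C)c(C)c3oc2=O)ccc1O` gives 570 nM which lies within the scatter of compound 1 and well under compound 2. Compound 4 `COC(=O)CNCCCOc1ccc2cc(NC(=O)c3ccc(O)c(CC=C(C)C)c3)c(=O)oc2c1C` differs from compound 3 on a saturated chain carbon, three bonds along the chain from an oxygen on an aromatic ring, with ((methoxycarbonyl)methyl)amino in place of isopropyl(methyl)amino on a saturated chain carbon, three bonds along the chain from an oxygen on an aromatic ring at that place. Going by the values given here, the measured amine changes span a 1.3-fold lower number from compound 1 to compound 3 (0.10 log units; within the scatter) and a 6.8-fold higher number from compound 1 to compound 2 (0.83 log units; beyond the scatter) and also an 8.6-fold lower number from compound 2 to compound 3 (0.93 log units; beyond the scatter) as the steps that bear on it. Among the compounds with values here, compound 4 keeps a hydrogen on the amine nitrogen, as compound 1 does, but no measured compound carries a methoxycarbonyl group. A modest rise is therefore expected, estimated as a 2.6-fold higher number from compound 3 to compound 4 (0.42 log units; beyond the scatter) with real uncertainty. In this assay compound 4 is estimated at 1500 nM with an expected range from 500 nM to 4500 nM as its likely span.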

Compound 4, half-maximal inhibitory concentration: 1060 nM
The estimate for compound 4 lay 1.4-fold (0.15 log units) above the measured number; measured number inside the range.
By their numbers in this assay, from the lowest: compounds 3, 1 and 4 (each within the scatter of the next); then compound 2.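

In this assay this position accepts a methoxycarbonyl group on the amine side chain without a change beyond the scatter, whether compared with isopropyl(methyl)amino (a 1.9-fold higher number from compound 3 to compound 4 (0.27 log units; within the scatter)) or with methyl in place of methoxycarbonyl on the saturated chain carbon bound to the amine nitrogen (a 1.5-fold higher number from compound 1 to compound 4 (0.17 log units; within the scatter)). The same change from diethylamino gives a step beyond the scatter (a 4.6-fold lower number from compound 2 to compound 4 (0.66 log units; beyond the scatter)), so among the four amines shown only diethylamino stands apart. Nothing measured here accounts for these numbers. The compounds shown leave open whether a carboxylic acid in place of the methoxycarbonyl group, or a longer chain between the oxygen and the amine, would stay at this level.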